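Methoxy to isopropyl on the benzyloxy arm of compound 2

The source may report more compounds than this note shows. Statements on the series, on what has been measured and on what is new or still open speak of the compounds shown alone.

Measured compounds:
compound 1, `CCCCCCCCCCCCCOc1cccc(N2C(N)=NC(N)=NC2(C)C)c1`, 6.52
compound 2, `COc1cccc(OCc2cccc(N3C(N)=NC(N)=NC3(C)C)c2)c1`, 5.36

Both compounds were run in a functional assay on L5178Y cells (Mus musculus); a higher number here means a more potent compound, by a factor of ten per unit of this negative logarithm, a lower number a less potent compound. Compound 2 gives the lower of the two numbers; compound 1 stands higher, and the gap of the two lies beyond the usual scatter. Among the measured compounds shown here, no two measured compounds here differ in only one place, so no single step can be read off directly.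

Compound 3, `CC(C)c1cccc(OCc2cccc(N3C(N)=NC(N)=NC3(C)C)c2)c1`, is the next member of the series and has not been measured. Against compound 2 the change is isopropyl in place of methoxy on an aromatic carbon. For the measured compounds named here, nothing among the measured compounds shows this exact change. What can be said is that compound 1, which carries the longest carbon chain in the set, sits highest with 6.52, while compound 2 with the methoxy-bearing arm gives 5.36. On that basis a small rise is expected for compound 3, of about a number 0.34 log units higher from compound 2 to compound 3 (beyond the scatter), close to the scatter. The estimate for compound 3 in this assay is 5.7, with a range from 5.2 to 6.3.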

Compound 3, logarithm of the reciprocal of the active concentration, log(1/C): 5.87
Beside the measured number, compound 3's estimate is 0.17 log units below it, and the stated range covers the measured number.
By their numbers in this assay, from the lowest: compound 2; then compound 3; then compound 1.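

Isopropyl in place of methoxy, on an aromatic carbon meta to a large group, gives in this assay a number 0.51 log units higher from compound 2 to compound 3 (beyond the scatter), a modest step and the first in the series that can be read from a change in one place. This position therefore does not leave the number unchanged: the value moves when methoxy, with its oxygen and one hydrogen-bond acceptor, gives way to isopropyl, an all-carbon group with one more heavy atom and no hydrogen-bond acceptor. Nothing measured here explains the step, and no separate data bear on its cause.

This one step cannot separate the loss of the oxygen from the gain in carbon, since both happen together between the two compounds. An ethyl or tert-butyl group at this position would test the carbon count without the oxygen, while an amine or a carboxylic acid there would show how this assay responds to groups of a quite different kind.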